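Taking the chloro off compound 3

The compounds below may be only part of what the source reports. "The series", "measured", "known", "first", "only" and "open" are said of these compounds alone.

Working notes on the series. Of the compounds shown here, three have numbers so far: compound 1 `C[C@H]1CC[C@@H]2[C@@H](OC(=O)[C@]23CC(c2ccc([N+](=O)[O-])cc2)=NO3)[C@]2(C)C(=O)C=C[C@@]12O`, compound 2 `Cc1ccccc1C1=NO[C@]2(C1)C(=O)O[C@@H]1[C@H]2CC[C@H](C)[C@]2(O)C=CC(=O)[C@@]12C` and compound 3 `C[C@H]1CC[C@@H]2[C@@H](OC(=O)[C@]23CC(c2ccc(Cl)cc2)N(c2ccccc2)O3)[C@]2(C)C(=O)C=C[C@@]12O`. In a physicochemical assay for lipophilicity (on this read-out higher numbers stand for higher lipophilicity and lower numbers for lower lipophilicity), compound 1 gives 1.37 and compound 2 gives 1.86. Compound 3 gives 3.87, the highest of the three and clear of both others beyond the scatter.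

Compound 4 `C[C@H]1CC[C@@H]2[C@@H](OC(=O)[C@]23CC(c2ccccc2)N(c2ccccc2)O3)[C@]2(C)C(=O)C=C[C@@]12O` has no number yet. Its difference from compound 3 is hydrogen in place of chloro on an aromatic carbon.

Among the measured compounds shown here, only one measured step offers any guide, and that guide is indirect: a number 0.49 log units higher from compound 1 to compound 2 (beyond the scatter). For the measured compounds named here, that step involves a different change, and no measured pair loses a chloro, so its size serves only as a rough scale. From the structural change itself, a drop of similar or somewhat larger size is expected, beyond the scatter. The expected step is a number 0.62 log units lower from compound 3 to compound 4 (beyond the scatter). Compound 4 is estimated at 3.25, with an expected range of 2.85 to 3.6.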

Compound 4, partition coefficient: 3.19
The estimate for compound 4 lay 0.06 log units above the measured number; the range from low to high includes it.
By their numbers in this assay, from the lowest: compound 1; then compound 2; then compound 4; then compound 3.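

In this assay, among the compounds shown here, going from 4-chlorophenyl to phenyl, on an aromatic carbon para to a large group, gives a number 0.68 log units lower from compound 3 to compound 4 (beyond the scatter) as the first measured step at this position. The chloro therefore counts here: this one change, which removes a single heavy atom and leaves the rest of the structure untouched, gives a modest step. For the compounds shown here, nothing measured so far gives a reason for the size of this step.

Going by these compounds, whether an amine, a carboxylic acid or a methoxy group on this same aromatic carbon would move the number in this assay up or down remains open. Also open, on these data alone, is whether 4-chlorophenyl to phenyl gives a step of similar size on the carbon with a double bond to nitrogen, as in the core of compound 1.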